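Trimethoxyphenyl swap on the 3-chloroanilino core

A few compounds are considered here, and "the series" means these few. Any claim that something is new, unique, unknown or untested is made for them only; others in the source may bear on it.

Three analogues of one shared core have been measured in a functional assay on MGC-803 cells (Homo sapiens) for inhibition, read by MTT assay, with a stated time of 72 h; a higher number here means a weaker inhibitor, a lower number a stronger inhibitor. Compound 1 `CC(C)c1ccc(-c2nc(SCc3cn(CC(=O)NC(=O)Nc4ccccn4)nn3)nc(Nc3ccccc3Cl)c2C#N)cc1` gives 19700 nM. Compound 2 `CC(C)c1ccc(-c2nc(SCc3cn(CC(=O)NC(=O)Nc4ccccn4)nn3)nc(Nc3cccc(Cl)c3)c2C#N)cc1` reaches only the limit of the assay, > 64000 nM. Compound 3 `COc1ccccc1Nc1nc(SCc2cn(CC(=O)NC(=O)Nc3ccccn3)nn2)nc(-c2ccc(C(C)C)cc2)c1C#N` likewise stops at the limit, > 64000 nM. The step of an at least 3.2-fold higher number from compound 1 to compound 2 (0.51 log units; beyond the scatter) and the step of an at least 3.2-fold higher number from compound 1 to compound 3 (0.51 log units; beyond the scatter) both run toward the limit, so compound 2 stands at the weak end of the numbers shown, sharing that limit with compound 3 (the limit of > 64000 nM in this assay, at which 2 of the 3 values shown sit); the step that the two limits leave unreadable from compound 2 to compound 3 cannot be read between two limits.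

Compound 4 `COc1cc(-c2nc(SCc3cn(CC(=O)NC(=O)Nc4ccccn4)nn3)nc(Nc3cccc(Cl)c3)c2C#N)cc(OC)c1OC` keeps the (3-chlorophenyl)amino group of compound 2 and changes the other aryl group: 3,4,5-trimethoxyphenyl in place of 4-isopropylphenyl on an aromatic carbon. For the measured compounds named here, none of the measured steps touches this position; all three alter the group on the nitrogen. Going by the values given here, the change therefore has no measured precedent in this set, and the starting point is itself a limit. Expected for compound 4 is a value that remains close to that limit, an estimated step of a number no higher from compound 2 to compound 4 (the limit leaves the size open) of no readable size. Compound 4 is accordingly estimated at 64000 nM, with a range from 20000 nM to 200000 nM, and more likely than not another limit rather than a number.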

Compound 4, half-maximal inhibitory concentration: 15400 nM
For compound 4 the middle estimate is 4.2-fold (0.62 log units) above the measured one; the whole stated range lies above it.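

In this assay, the aromatic carbon ortho to a cyano group is shown for the first time to affect the read-out: 3,4,5-trimethoxyphenyl in place of 4-isopropylphenyl gives an at least 4.1-fold lower number from compound 2 to compound 4 (0.61 log units; beyond the scatter). For the compounds shown here, the earlier steps all altered the group on the nitrogen, so this is the first evidence that the aryl group at this carbon also matters, and with the (3-chlorophenyl)amino group held fixed, the change turns a limit into a measured number. Compound 2 gives > 64000 nM, which is a limit, so this step has a minimum size and no exact one: the limit of > 64000 nM in this assay, at which 2 of the 4 values shown sit.

The compounds shown do not settle whether the change depends on all three methoxy groups, or whether a single methoxy group, a hydroxyl group or an amine on this aryl ring would give a similar reading. Also open, going by these compounds, is whether 3,4,5-trimethoxyphenyl would give a similar step alongside the (2-chlorophenyl)amino group of compound 1, and the step between the two limits, from compound 2 to compound 3, cannot be read.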